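From a Thioether to a Benzylamine on the Shared Core

The compounds below may be only part of what the source reports. "The series", "measured", "known", "first", "only" and "open" are said of these compounds alone.

Compound 1, `Nc1cc(N)c2nc(-c3ccccc3)c(Sc3ccc(F)cc3)nc2c1`, is known in a functional assay on UO-31 cells (Homo sapiens) for inhibition, read by sulforhodamine B assay, with a stated time of 48 h (a higher number here means a weaker inhibitor of growth, a lower number a stronger inhibitor of growth), only as a limit, < 100000 nM. Compound 3, `CCOC(=O)[C@H](CCC(=O)O)NC(=O)c1ccc(CNc2nc3cc(N)cc(N)c3nc2-c2ccccc2)cc1`, likewise reaches only a limit in this assay, < 100000 nM. Going by the values given here, the single numeric value belongs to compound 2, `COc1cc(CNc2nc3cc(N)cc(N)c3nc2-c2ccccc2)cc(OC)c1OC`, which in this assay gives 11200 nM. Within this small set, compound 1 therefore stands at the limit of < 100000 nM in this assay, at which 2 of the 3 values shown sit. Compound 4, `Nc1cc(N)c2nc(-c3ccccc3)c(NCc3ccc(F)cc3)nc2c1`, differs from compound 1 in one place: (4-fluorobenzyl)amino in place of (4-fluorophenyl)sulfanyl on an aromatic carbon. Among the compounds with values here, because compound 2, the only compound with a number, gives 11200 nM, compound 4 is expected to lie near that value. For compound 4 the expected value in this assay is 15000 nM, with a range from 3000 nM to 80000 nM. The expected step is a step that the limit leaves unreadable from compound 1 to compound 4.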

Compound 4, concentration for 50% growth inhibition: 3800 nM
Compound 4: middle estimate off by 3.9-fold (0.60 log units), on the high side, within the range that was stated.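

The step from compound 1 to compound 4 cannot be read, because compound 1 is known only as a limit: the limit of < 100000 nM in this assay, at which 2 of the 4 values shown sit.

The compounds shown leave open how far (4-fluorobenzyl)amino in place of (4-fluorophenyl)sulfanyl shifts growth inhibition in this assay on the shared core.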